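A few compounds are considered here, and "the series" means these few. Any claim that something is new, unique, unknown or untested is made for them only; others in the source may bear on it.

Three compounds built on one shared core, and a fourth not yet tested, are compared in an ADME assay on A549 cells (Homo sapiens) for cytotoxicity, read by CellTiter-Glo; on this read-out lower numbers stand for higher toxicity in this test and higher numbers for lower toxicity in this test. Compound 1 `Cc1c(Cc2ccc(F)cc2F)c(=O)oc2cc(OCC(O)CN3CCC(C(N)=O)CC3)ccc12` carries a 2,4-difluorobenzyl group, and in this assay compound 1 is reported only as a limit of the assay, > 100000 nM, not as a number. Compound 2 `Cc1c(Cc2ccc(F)cc2Cl)c(=O)oc2cc(OCC(O)CN3CCC(C(N)=O)CC3)ccc12` differs from compound 1 in one place, (chloro in place of fluoro on an aromatic carbon), and in this assay compound 2 gives 90800 nM. That change made an at least 1.1-fold lower number from compound 1 to compound 2 (0.04 log units; that floor lies within the scatter). Compound 3 `Cc1c(Cc2ccc(-c3ccc(F)cc3)cc2)c(=O)oc2cc(OCC(O)CN3CCC(C(N)=O)CC3)ccc12` carries a 4-fluorophenyl group instead; the difference between the core of compound 3 and that of compound 1 is not broken down here. In this assay compound 3 gives 19300 nM, the lowest number among the three, with compound 2 as its nearest neighbour.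

Compound 4 `Cc1c(Cc2ccc(-c3ccc(Cl)cc3)cc2)c(=O)oc2cc(OCC(O)CN3CCC(C(N)=O)CC3)ccc12` is the one still to be measured. It differs from compound 3 by chloro in place of fluoro on an aromatic carbon. This is the same kind of change as from compound 1 to compound 2, though the surroundings differ: there the entering chloro stood ortho to a large group and meta to a fluoro group, here it stands para to a large group. The step from compound 3 to compound 4 is expected to be small, a 1.2-fold lower number from compound 3 to compound 4 (0.08 log units; within the scatter), because the like change earlier gave an at least 1.1-fold lower number from compound 1 to compound 2 (0.04 log units; that floor lies within the scatter). Compound 4 is therefore estimated at 16000 nM, with a likely range from 6000 nM to 45000 nM.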

Compound 4, half-maximal cytotoxic concentration: 32900 nM
For compound 4 the middle estimate is 2.1-fold (0.31 log units) below the measured one; measured number inside the range.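

Turning the 4-fluorophenyl group into a 4-chlorophenyl group gives, in this assay, a 1.7-fold higher number from compound 3 to compound 4 (0.23 log units; within the scatter); a step of this size cannot be told apart from the ordinary spread of repeated measurements. Set beside the earlier case, the two steps cannot be firmly compared, since one end of the first is not a number: the same change on two cores in this assay, an at least 1.1-fold lower number (0.04 log units; that floor lies within the scatter) from compound 1 to compound 2 and a 1.7-fold higher number (0.23 log units; within the scatter) from compound 3 to compound 4; the limit leaves it open whether they differ Neither printed step goes beyond the scatter, but this does not show that the change carries over unaltered from one core to another, and the true size of the first step stays unknown, as compound 1 is reported only as a limit: the limit of > 100000 nM in this assay, at which 1 of the 4 values shown sits.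

The compounds shown leave open how this assay would read with a methyl, methoxy or nitrile group in place of the halogen on the 4-fluorophenyl or 4-chlorophenyl group. They also leave open whether a carboxylic acid in place of the amide on the shared side chain would alter the read-out, and whether the swap from fluoro to chloro would give a step of similar size with that group present.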